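From 1-aminopropyl to 1-amino-2-methylpropyl on the shared core

The source may report more compounds than this note shows. Statements on the series, on what has been measured and on what is new or still open speak of the compounds shown alone.

In an in vitro ADME assay on microsomes (Homo sapiens) for metabolic stability (on this read-out lower numbers stand for a shorter-lived compound and higher numbers for a longer-lived compound), compound 1 `CC(=O)N1CCc2c(C)c3c(n2-c2ccc(C(N)=O)c(c2)N[C@@H](C)[C@H](C)C1)CC(C)(C)CC3=O` gives 0.05 h. Compound 2 `Cc1c2c(n3c1CCN(C(=O)CN)C[C@@H](C)[C@H](C)Nc1cc-3ccc1C(N)=O)CC(C)(C)CC2=O` reads > 0.5 h, which is a limit of the assay and not a number. Compound 3 `CC[C@H](N)C(=O)N1CCc2c(C)c3c(n2-c2ccc(C(N)=O)c(c2)N[C@@H](C)[C@H](C)C1)CC(C)(C)CC3=O` gives 0.417 h, the higher of the two exact numbers, and clearly beyond the scatter from compound 1.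

Compound 4 `Cc1c2c(n3c1CCN(C(=O)[C@@H](N)C(C)C)C[C@@H](C)[C@H](C)Nc1cc-3ccc1C(N)=O)CC(C)(C)CC2=O` brings one further change, (methyl in place of hydrogen on a saturated chain carbon bound to two saturated chain carbons). This turns 1-aminopropyl into 1-amino-2-methylpropyl.

Two measured steps show large gains when the side chain gains an amino group: an at least 10-fold higher number from compound 1 to compound 2 (1.00 log units; beyond the scatter), and an 8.3-fold higher number from compound 1 to compound 3 (0.92 log units; beyond the scatter). Among the measured compounds shown here, the closest precedent for the new change is the addition of ethyl to that chain, an at least 1.1-fold lower number from compound 2 to compound 3 (0.07 log units; that floor lies within the scatter), whose floor lies within the scatter. With that small step as the guide, only a small further addition of carbon should not shift the number much.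

No change beyond the scatter is expected, so the estimated step is a 1.1-fold higher number from compound 3 to compound 4 (0.03 log units; within the scatter). In this assay, the estimate for compound 4 is 0.45 h, with an expected range from 0.22 h to 0.9 h.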

Compound 4, half-life: 0.133 h
For compound 4 the middle estimate is 3.4-fold (0.53 log units) above the measured one, and the stated range ends above it.
By their numbers in this assay, from the lowest: compound 1; then compound 4; then compound 3. At a limit, above all of these: compound 2.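

Among the compounds shown here, on this saturated chain carbon, the side chain proves less forgiving in this assay than the earlier compounds suggested: the one methyl that turns ethyl into isopropyl gives a 3.1-fold lower number from compound 3 to compound 4 (0.50 log units; beyond the scatter). Set against the bare hydrogen, isopropyl gives an at least 3.7-fold lower number from compound 2 to compound 4 (0.57 log units; beyond the scatter), and that step is only a floor, as compound 2 stands at a limit of the assay: the limit of > 0.5 h in this assay, at which 1 of the 4 values shown sits. Part of the gain from the amino-bearing side chain still remains, with a 2.7-fold higher number from compound 1 to compound 4 (0.42 log units; beyond the scatter).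

As far as these compounds go, whether the branching or simply the added carbon drives this drop stays open, and a straight propyl chain on that carbon would help separate the two. A hydroxyl group in place of the amino group would also test whether the gain over compound 1 depends on that amine.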